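The source may hold more compounds than are shown below. What is called first, only, known or untested is meant among the compounds shown, and "the series" means these compounds.

For the measured compounds named here, compound 3, `N#CC1=C(N)Oc2c(N)cc3nc4ccccc4nc3c2C12C(=O)N(Cc1cnnn1-c1cccc(C(F)(F)F)c1)c1ccccc12`, is the one compound here with a numerical result: in a functional assay on A549 cells (Homo sapiens) for antiproliferative activity, read by MTT assay, with a stated time of 48 h (on this read-out lower numbers stand for stronger inhibition and higher numbers for weaker inhibition), compound 3 gives 5400 nM. Compound 1, `N#CC1=C(N)Oc2c(c3nc4ccccc4nc3c3ccccc23)C12C(=O)N(Cc1cnnn1-c1ccc(N)cc1)c1ccccc12`, gives only a limit of the assay, > 50000 nM. Compound 2, `Cc1ccc(-n2nncc2CN2C(=O)C3(C(C#N)=C(N)Oc4c3c3nc5ccccc5nc3c3ccccc43)c3ccccc32)cc1C`, likewise gives only a limit, > 50000 nM. Going by the values given here, the single measured step, a step that the two limits leave unreadable from compound 1 to compound 2, cannot be sized because both of its values sit at the limit of > 50000 nM in this assay, at which 2 of the 3 values shown sit. Among the compounds with values here, compound 3 therefore stands alone with the only real number among the three.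

Compound 4, `Cc1ccc(Cl)cc1-n1nncc1CN1C(=O)C2(C(C#N)=C(N)Oc3c(N)cc4nc5ccccc5nc4c32)c2ccccc21`, differs from compound 3 in one place: 5-chloro-2-methylphenyl in place of 3-(trifluoromethyl)phenyl on an aromatic nitrogen. Within the data shown here, no measured step tests a change of this kind, since the one step recorded concerns a different pair and is unreadable. With nothing pointing either way, the step of a 1.1-fold higher number from compound 3 to compound 4 (0.05 log units; within the scatter) from compound 3 to compound 4 is expected to stay within the usual scatter. Compound 4 is thus estimated to give 6000 nM in this assay, with a range from 2000 nM to 20000 nM.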

Compound 4, half-maximal inhibitory concentration: > 50000 nM
Compound 4 gave a limit, no number; the forecaster's own chance of this, stated with the estimate: 15%; at least 8.3-fold (0.92 log units) between middle value and limit.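

In this assay, the change on this aromatic nitrogen gives an at least 9.2-fold higher number from compound 3 to compound 4 (0.96 log units; beyond the scatter), the first step among these compounds that can be read at all. Compound 4 gives > 50000 nM, which is a limit of the assay and not a number. On this shared core, then, the group on that nitrogen matters: 3-(trifluoromethyl)phenyl in compound 3 gives a number, 5-chloro-2-methylphenyl in compound 4 does not, and compound 3 stays alone: the limit of > 50000 nM in this assay, at which 3 of the 4 values shown sit.

On these data alone, the trifluoromethyl group leaves as the chlorine and methyl enter, so it remains open which of them counts, and how a plain phenyl ring on the core of compound 3 would behave. As far as these compounds go, the step from compound 1 to compound 2 cannot be read, and the effect of a carboxylic acid on this ring also remains open.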